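Swapping the aryl thioether in a benzamide series

The source may report more compounds than this note shows. Statements on the series, on what has been measured and on what is new or still open speak of the compounds shown alone.

Measured so far:
- compound 1 `Nc1ccccc1NC(=O)c1ccc(CSc2nccc(C(F)(F)F)n2)cc1` — 80.6%
- compound 2 `COc1ccc(SCc2ccc(C(=O)Nc3ccccc3N)cc2)cc1` — 80.1%
- compound 3 `Nc1ccccc1NC(=O)/C=C/c1ccc(CSc2cccc(F)c2)cc1` — 8.25%

Of the compounds shown here, three have been tested in a functional assay on SMMC-7721 cells (Homo sapiens) for inhibition, read by CCK-8 assay, with a stated time of 72 h, tested at 8 uM; a higher number here means more inhibition of growth at the concentration tested, a lower number less inhibition of growth. Compound 1 gives 80.6% and compound 2 gives 80.1%; the two numbers lie within the scatter of each other, so neither can be called the stronger. Compound 3, which carries a different linker between the core and the amide, gives 8.25%, far below the other two. Compound 2 thus stands second highest of the three, separated from compound 1 by a gap that is not meaningful and from compound 3 by one that is.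

Compound 4 `Cc1cc(C)cc(SCc2ccc(C(=O)Nc3ccccc3N)cc2)c1` has not been measured. It differs from compound 2 in one place: 3,5-dimethylphenyl in place of 4-methoxyphenyl on a sulfur. Compound 1 and compound 2 show that two rather different groups on that sulfur give about the same growth inhibition, so a third aryl group there is expected to behave similarly. The step of a number 8.1 percentage points lower from compound 2 to compound 4 (within the scatter) is estimated to be small and, if anything, slightly downward, within the scatter. In this assay compound 4 is therefore expected to give about 72%, most likely between 45% and 88%.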

Compound 4, percent growth inhibition at one concentration: 85.1%
Compound 4: middle estimate off by 13.1 percentage points, on the low side; the range from low to high includes it.
By their numbers in this assay, from the lowest: compound 3; then compounds 2, 1 and 4 (each within the scatter of the next).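

In this assay, the step of a number 5 percentage points higher from compound 2 to compound 4 (within the scatter) comes with 3,5-dimethylphenyl in place of 4-methoxyphenyl on a sulfur, so this one change leaves growth inhibition unresolved from the scatter. The entering group has no oxygen and no hydrogen-bond acceptor, yet compound 4 still gives 85.1% in this assay, which shows that growth inhibition at this level does not require the methoxy oxygen of compound 2 at this position. No supporting data bear on why the two aryl groups read alike.

The compounds shown leave open whether this tolerance extends beyond carbon-ring aryl groups carrying methyl or methoxy substituents, for example to an aryl group bearing an amine or a carboxylic acid, or to a longer saturated chain on the sulfur. They also leave open whether the two aryl groups would remain indistinguishable at lower concentrations, since a single concentration gives no full concentration-response comparison.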